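A few compounds are considered here, and "the series" means these few. Any claim that something is new, unique, unknown or untested is made for them only; others in the source may bear on it.

Compound 1 `Cc1ccc(C2=NN(c3ccc(S(C)(=O)=O)cc3)C(=O)CC2)cc1` gives > 100000 nM in a functional assay on UACC-62 cells (Homo sapiens) for inhibition, read by sulforhodamine B assay, with a stated time of 48 h (a higher number here means a weaker inhibitor of growth, a lower number a stronger inhibitor of growth), which is a limit of the assay. Compound 2 `Cc1cc(O)ccc1C1=NN(c2ccc(S(C)(=O)=O)cc2)C(=O)CC1` gives > 100000 nM, again a limit and not a number, and this is all that is known of where it stands. Compound 3 `CCc1ccc(C2=NN(c3ccc(S(C)(=O)=O)cc3)C(=O)CC2)cc1` has 4-ethylphenyl in place of 4-hydroxy-2-methylphenyl on a carbon with a double bond to nitrogen. Among the compounds with values here, the one measured step is a step that the two limits leave unreadable from compound 1 to compound 2, and the only evidence is the limit of > 100000 nM in this assay, at which 2 of the 2 values shown sit. No clear step in either direction is therefore expected in this assay, and the expected change is an at least 1.2-fold lower number from compound 2 to compound 3 (0.09 log units; that floor lies within the scatter). For compound 3 the estimated value is 80000 nM, with an expected range from 30000 nM to 100000 nM.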

Compound 3, concentration for total growth inhibition: > 100000 nM
Compound 3 ended at the assay's limit (the forecaster's own chance of this, stated with the estimate: 75%); middle value at least 1.2-fold (0.09 log units) from the limit.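

Compound 1, compound 2 and compound 3 all stand at a limit of this assay, not at a number, so no step among them can be read: the limit of > 100000 nM in this assay, at which 3 of the 3 values shown sit.

From the compounds shown here alone, how far apart the three compounds truly lie, and whether 4-methylphenyl, 4-hydroxy-2-methylphenyl or 4-ethylphenyl changes growth inhibition at all, stays open.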